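A Methoxy Group Added to the Phenyl of Compound 1

The source may hold more compounds than are shown below. What is called first, only, known or untested is meant among the compounds shown, and "the series" means these compounds.

Compound 1, `COc1cc(/C=C/C(=O)c2cccc(-n3cc(-c4ccccc4)[nH]c3=O)c2)ccc1O`: 3040 nM
Compound 2, `O=C(/C=C/c1cccc(O)c1)c1cccc(-n2cc(-c3ccccc3)[nH]c2=O)c1`: 18200 nM
Compound 3, `COc1cc(/C=C/C(=O)c2cccc(-n3cc(-c4ccccc4)[nH]c3=O)c2)cc(OC)c1OC`: 1900 nM

In a functional assay on SF-295 cells (Homo sapiens) for inhibition (on this read-out higher numbers stand for weaker inhibition of growth and lower numbers for stronger inhibition of growth), compound 1 gives the second highest of the three numbers. Compound 3 lies nearest, within the scatter, and the step of a 6.0-fold higher number from compound 1 to compound 2 (0.78 log units; beyond the scatter) is the only one beyond the scatter. Compound 4, `COc1ccc(-c2cn(-c3cccc(C(=O)/C=C/c4ccc(O)c(OC)c4)c3)c(=O)[nH]2)cc1`, differs from compound 1 by methoxy in place of hydrogen on an aromatic carbon; cut one bond further out, this reads phenyl to 4-methoxyphenyl. Going by the values given here, no measured step touches this phenyl: the single known step alters the other aryl group. With nothing bearing on the change, no step beyond the scatter is expected in this assay. Compound 4 is therefore estimated at 3000 nM, in the range 1000 nM to 9000 nM, an expected step of a 1.0-fold lower number from compound 1 to compound 4 (0.01 log units; within the scatter).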

Compound 4, concentration for 50% growth inhibition: 13900 nM
For compound 4 the middle estimate is 4.6-fold (0.67 log units) below the measured one; the measured number lies above the stated range.
By their numbers in this assay, from the lowest: compounds 3 and 1 (each within the scatter of the next); then compounds 4 and 2 (each within the scatter of the next).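

The phenyl of compound 1 proves sensitive to substitution in this assay: methoxy in place of hydrogen on an aromatic carbon, para to a large group, gives a 4.6-fold higher number from compound 1 to compound 4 (0.66 log units; beyond the scatter) and so weakens inhibition of growth. Going by these compounds alone, the earlier step had changed only the other aryl group, so this is the first reading at this ring. Nothing at hand accounts for the step.

From the compounds shown here alone, whether any group at this place weakens inhibition, or methoxy alone, stays open; fluorine, hydroxyl or an amine on the same carbon would separate the two. Going by these compounds, it is also open whether the step would hold with the other aryl group of compound 3.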